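Chalcone-pyrazole series: cytotoxicity notes

The source may report more compounds than this note shows. Statements on the series, on what has been measured and on what is new or still open speak of the compounds shown alone.

Measured so far:
compound 1 `COc1cc(-c2cc(/C=C/C(=O)c3ccc(N)cc3)[nH]n2)cc(OC)c1OC`, value 102%
compound 2 `COc1ccc(-c2cc(/C=C/C(=O)c3cc(OC)c(OC)c(OC)c3)[nH]n2)cc1OC`, value 100%

In a functional assay on NCI-H460 cells (Homo sapiens) for cytotoxicity, read by sulforhodamine B assay, with a stated time of 48 h, tested at 0.01 uM (a higher number here means a weaker effect of the compound at the concentration tested, a lower number a stronger effect), compound 1 gives 102%. In this assay compound 2 gives 100%. Compound 1 has the higher of the two numbers, but its gap to compound 2 is within the scatter, so the two cannot be ordered against each other. Both numbers point to only a weak effect at the concentration tested.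

Compound 3 `COc1ccc(C(=O)/C=C/c2cc(-c3cc(OC)c(OC)c(OC)c3)n[nH]2)cc1OC` is not yet measured. Against compound 1 the change is 3,4-dimethoxyphenyl in place of 4-aminophenyl on a carbonyl carbon. Among the measured compounds shown here, no step between two measured compounds is available to calibrate a change of this kind, so the expectation rests on the two values alone. Compound 2 also carries a 3,4-dimethoxyphenyl group and sits within scatter of compound 1, which gives no sign that this group moves the read-out. The expected step is none beyond the scatter, a number 2 percentage points lower from compound 1 to compound 3 (within the scatter). For compound 3 the estimate is 100%. The expected range for compound 3 runs from 90% to 110%.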

Compound 3, a percentage reported as activity, at one concentration (the size of the read-out at that concentration, not a potency): 103%
For compound 3 the middle estimate is 3 percentage points below the measured one, and the stated range covers the measured number.
By their numbers in this assay, from the lowest: compounds 2, 1 and 3 (each within the scatter of the next).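

In this assay, among the compounds shown here, the first directly readable step at this position, with 3,4-dimethoxyphenyl in place of 4-aminophenyl on a carbonyl carbon, is a number 1 percentage points higher from compound 1 to compound 3 (within the scatter) and so shows no separation between the two groups. The earlier pair offered only an indirect hint that 3,4-dimethoxyphenyl leaves the read-out unmoved, whereas this one-place comparison shows that the 4-aminophenyl group can be exchanged for a larger group without a detectable shift at the single concentration tested, although all three compounds show only a weak effect there, so a difference between the groups at other concentrations cannot be read from this step. Nothing available explains why the read-out stays flat on this exchange.

As far as these compounds go, whether any group on this carbonyl carbon can move the read-out remains open, for example a 4-carboxyphenyl group, a 4-hydroxyphenyl group or a longer chain ending in an amine. The step also leaves open whether the substituents on the other aryl ring of the shared core matter more than those at this position.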